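The source may hold more compounds than are shown below. What is called first, only, known or untested is meant among the compounds shown, and "the series" means these compounds.

Among the compounds with values here, in an ADME assay on microsomes from liver (Mus musculus) for metabolic stability (a higher number here means that the compound lasts longer, a lower number that the compound disappears faster), compound 1 `CC(C)C(Nc1nnc[nH]1)c1ccc(-c2ccc3cccc(F)c3c2)[nH]c1=O` gives 2.42 h, the only exact number among the three compounds measured. Compound 2 `CCn1ncc2c(F)cc(-c3ccc(C(CC)(CC)c4nnc(C)[nH]4)c(=O)[nH]3)cc21` reads > 3 h, which is a limit of the assay. Compound 3 `CCn1ncc2c(F)cc(-c3ccc(C(CC)(CC)c4nncn4C)c(=O)[nH]3)cc21` reads > 3 h, also a limit. Compound 1 therefore stands close to the limit of > 3 h in this assay, at which 2 of the 3 values shown sit. Compound 4 `CC(C)C(c1nnc[nH]1)c1ccc(-c2ccc3cccc(F)c3c2)[nH]c1=O` differs from compound 1 by a single change, 4H-1,2,4-triazol-3-yl in place of (4H-1,2,4-triazol-3-yl)amino on a saturated chain carbon bound to an aromatic carbon and a saturated chain carbon: 4H-1,2,4-triazol-3-yl in place of (4H-1,2,4-triazol-3-yl)amino on a saturated chain carbon. Within the data shown here, the one measured step, a step that the two limits leave unreadable from compound 2 to compound 3, concerns a different change and gives no size to carry over. In this assay, the expected step of a 1.1-fold higher number from compound 1 to compound 4 (0.03 log units; within the scatter) therefore stays within the scatter, with no direction favoured. Compound 4 is estimated at 2.6 h, with an expected range of 1.3 h to 5 h.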

Compound 4, half-life: 0.213 h
Compound 4: the middle estimate sits 12-fold (1.09 log units) above what was measured; measured number outside the range, below it.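

In this assay, setting 4H-1,2,4-triazol-3-yl in place of (4H-1,2,4-triazol-3-yl)amino on a saturated chain carbon gives an 11-fold lower number from compound 1 to compound 4 (1.06 log units; beyond the scatter). Within the data shown here, this is the first step here with a readable size, and it shows that, for this pair, the amino link is no neutral part of the group. Compound 2 and compound 3 each stay at a limit rather than a number: the limit of > 3 h in this assay, at which 2 of the 4 values shown sit.

Going by these compounds, whether a methylene or ether oxygen link in this place would behave like the amino link stays open. So does whether the step would carry over to the core of compound 2.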